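The source may report more compounds than this note shows. Statements on the series, on what has been measured and on what is new or still open speak of the compounds shown alone.

Measured so far:
compound 1 `Clc1ccc2[nH]cc(SC3CCNCC3)c2c1` gives 0.3 mg/kg in a functional assay on the whole organism with Mus musculus as the target, in the writhing test; a lower number here means that less compound is needed, a higher number that more compound is needed for the effect
compound 2 `CCOC(=O)N1CCC(Sc2c[nH]c3ccc(Br)cc23)CC1` gives 6.3 mg/kg in this assay
compound 3 `Cc1[nH]c2ccc(Cl)cc2c1SC1CCNCC1` gives 0.8 mg/kg in this assay

Going by the values given here, compound 3 stands second highest of the three numbers; its nearest neighbour is compound 1, and the one step that joins them, a 2.7-fold higher number from compound 1 to compound 3 (0.43 log units; beyond the scatter), is modest. Compound 2 lies further off, and since it differs from the others in two places at once, its value says only that the carbamate-bearing, bromo-substituted analogue needs more compound than either of the free amines.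

Compound 4 `Cc1[nH]c2ccc(F)cc2c1SC1CCNCC1` is the next analogue. Its change from compound 3 is fluoro in place of chloro on an aromatic carbon. Among the compounds with values here, no measured step in this set exchanges one halogen for another, so nothing here bears directly on it; the only recorded step concerns the methyl, and its size gives no guide to a halogen swap. In the absence of a precedent, the expected step is a 1.5-fold higher number from compound 3 to compound 4 (0.18 log units; within the scatter), within the scatter. Compound 4 is therefore estimated at 1.2 mg/kg, with a range from 0.5 mg/kg to 3 mg/kg.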

Compound 4, dose for half-maximal effect: 5.9 mg/kg
Estimate against measurement, compound 4: 4.9-fold (0.69 log units) below, outside the stated range (above it).
By their numbers in this assay, from the lowest: compound 1; then compound 3; then compounds 4 and 2 (each within the scatter of the next).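

In this assay the halogen on this aromatic carbon is not interchangeable: fluoro in place of chloro gives a 7.4-fold higher number from compound 3 to compound 4 (0.87 log units; beyond the scatter) and so exceeds the methyl step a 2.7-fold higher number from compound 1 to compound 3 (0.43 log units; beyond the scatter) in size. One heavy atom is exchanged for another, with no ring, hydrogen-bond donor, hydrogen-bond acceptor or net charge on either side, yet this alone is enough to shift the number, so this place on the shared core is sensitive to which halogen it carries. No measurement at hand accounts for the step.

From the compounds shown here alone, how a methoxy group or a nitrile on the same aromatic carbon would compare with chloro and fluoro stays open. So does whether the exchange of chloro for fluoro would bring a step of similar size on the core of compound 1, which has hydrogen where compound 3 has its methyl.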